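The source may report more compounds than this note shows. Statements on the series, on what has been measured and on what is new or still open speak of the compounds shown alone.

Compound 1 `CC1=CC[C@@H]([C@@](C)(O)CCCC(C)(C)NC=S)CC1` gives 9250 nM
Compound 2 `CC1=CC[C@@H]([C@@](C)(O)CCCC(C)(C)NC(=S)N/N=C\c2ccc(N(C)C)cc2)CC1` gives 19600 nM

In a functional assay on NCI-H460 cells (Homo sapiens) for cytotoxicity, read by sulforhodamine B assay (on this read-out higher numbers stand for weaker inhibition of growth and lower numbers for stronger inhibition of growth), compound 2 stands at the higher of the two numbers, and its gap to compound 1 lies beyond the usual scatter. The two measured compounds do not form a pair that differs in one place, so the data offer no direct guide to the next change. Compound 3 `CC1=CC[C@@H]([C@@](C)(O)CCCC(C)(C)NC(=S)N/N=C\c2ccc(Cl)cc2)CC1` differs from compound 2 by chloro in place of dimethylamino on an aromatic carbon, para to a large group (chloro in place of dimethylamino on an aromatic carbon). In this assay a small move toward a lower number is expected, possibly none beyond the scatter, and the estimate stays close to compound 2 (19600 nM). The estimated change is a modest one (a 1.6-fold lower number from compound 2 to compound 3 (0.21 log units; within the scatter)). For compound 3 the expected value is 12000 nM (estimated range 5000 nM to 25000 nM).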

Compound 3, concentration for 50% growth inhibition: 8720 nM
Compound 3: middle estimate off by 1.4-fold (0.14 log units), on the high side; the measured number falls inside the stated range.
By their numbers in this assay, from the lowest: compounds 3 and 1 (each within the scatter of the next); then compound 2.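

In this assay, for the compounds shown here, the exchange of 4-(dimethylamino)phenyl for 4-chlorophenyl gives a 2.2-fold lower number from compound 2 to compound 3 (0.35 log units; beyond the scatter) and is the only single-place step so far. The aromatic carbon para to a large group therefore responds to what it carries: chloro, with 1 heavy atom and 0 hydrogen-bond acceptors, goes with stronger inhibition of growth than dimethylamino, with 3 heavy atoms and 1 hydrogen-bond acceptor. No measurement available here accounts for this step.

One step cannot separate the removal of the dimethylamino group from the entry of chloro. As far as these compounds go, how this carbon responds to other groups, such as fluoro, methoxy, a primary amine or a carboxylic acid, remains open, as does whether the same step would hold on a different chain.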